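This account rests on a few compounds, and the source may have more. Where it says the series, first, only, none or still open, it means among the compounds named here.

Working notes on the series. The shared core is shown for compound 1 as `COc1ccc(C2C(OC(C)=O)C(=O)N2c2cc(OC)c(OC)c(OC)c2)cc1` and for compound 2 as `COc1ccc(C2C(OC(C)=O)C(=O)N2c2cc(OC)c(OC)c(OC)c2)cn1`. In a functional assay on IMR-32 cells (Homo sapiens) for cytotoxicity (on this read-out higher numbers stand for weaker inhibition and lower numbers for stronger inhibition), compound 1 gives 251 nM. For compound 2 this assay reports only a limit, > 1000 nM, and not a number, so compound 2 sits at the weaker edge of what has been measured (the limit of > 1000 nM in this assay, at which 1 of the 2 values shown sits). Within the data shown here, the one measured step, an at least 3.9-fold higher number from compound 1 to compound 2 (0.60 log units; beyond the scatter), is the only step that bears on the move to compound 3, `COc1cc(N2C(=O)C(OC(C)=O)C2c2ccc(N(C)C)cc2)cc(OC)c1OC`. The change from compound 2 to compound 3 is 4-(dimethylamino)phenyl in place of 6-methoxypyridin-3-yl on a saturated ring carbon. It removes the 6-methoxypyridin-3-yl whose arrival weakened compound 1 and brings in another six-membered aromatic ring of carbon only, so the step is expected to run the opposite way, toward lower numbers, at about an at least 4.0-fold lower number from compound 2 to compound 3 (0.60 log units; beyond the scatter). Since compound 2 is known only as a limit, the size of that step can be set no more closely than the distance back to compound 1. Compound 3 is estimated in this assay at 250 nM, with a range from 80 nM to 800 nM.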

Compound 3, half-maximal inhibitory concentration: 520 nM
Beside the measured number, compound 3's estimate is 2.1-fold (0.32 log units) below it; the range from low to high includes it.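

In this assay the saturated ring carbon of the four-membered ring now carries a second aromatic ring of carbon only, and this shows that such a ring alone does not settle the number there: dimethylamino in place of methoxy on an aromatic carbon gives a 2.1-fold higher number from compound 1 to compound 3 (0.32 log units; beyond the scatter) and marks the group on that aromatic ring as a change that registers beyond the scatter. Set against the 6-methoxypyridin-3-yl, the change gives an at least 1.9-fold lower number from compound 2 to compound 3 (0.28 log units; that floor lies within the scatter) and this is only a floor within the scatter, with no firm order for that pair of compounds. Compound 2 remains known as a limit only, and it is the one compound of the three that stands at the weaker edge of the measured range: the limit of > 1000 nM in this assay, at which 1 of the 3 values shown sits.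

Open, from the compounds shown here alone, is how the number responds to other groups on the same aromatic carbon, such as a hydroxyl, a primary amine or a fluorine in place of methoxy or dimethylamino. Also open, going by these compounds, is whether these steps would hold with a free hydroxyl in place of the acetoxy group on the neighbouring ring atom of the shared core.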